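Capping a Hydroxymethyl Group: Expected Thermal Shift

The compounds below may be only part of what the source reports. "The series", "measured", "known", "first", "only" and "open" are said of these compounds alone.

Among the measured compounds shown here, compound 2 `CCOc1ccc(C(C)=O)cc1NC(=O)c1cc(CO)cc(C(=O)O)c1` stands highest of the two compounds measured so far in an assay on isolated protein for binding affinity to histone acetyltransferase p300 (Homo sapiens), read by thermal shift assay, tested at 100 uM (a lower number here means that the compound stabilises the target less, a higher number that the compound stabilises the target more against heat), where compound 2 gives 3.7 degrees C. Compound 1 `CCOc1ccc(C(C)=O)cc1NC(=O)c1cccc(S(=O)(=O)Nc2ccccc2)c1` gives 0 degrees C in this assay, a gap beyond the scatter. Compound 3 `CCOc1ccc(C(C)=O)cc1NC(=O)c1cc(COC2CCCCO2)cc(C(=O)O)c1` differs from compound 2 by oxan-2-yl in place of hydrogen on an oxygen on a saturated carbon. For the measured compounds named here, no measured pair shows this change, so its size is unknown. The step of a number 1.2 degrees C lower from compound 2 to compound 3 (beyond the scatter) is expected to be a small decrease, possibly still within the scatter. Compound 3 is therefore expected to give 2.5 degrees C, within a range of 0 degrees C to 5 degrees C.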

Compound 3, shift of the target's melting temperature: 5.9 degrees C
Estimate against measurement, compound 3: 3.4 degrees C below, outside the stated range (above it).
By their numbers in this assay, from the lowest: compound 1; then compound 2; then compound 3.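

In this assay, oxan-2-yl on the oxygen of the hydroxymethyl group gives a number 2.2 degrees C higher from compound 2 to compound 3 (beyond the scatter) and so raises the number rather than lowering it. The hydrogen on that oxygen is therefore not required for the stabilisation seen with compound 2, and this position accepts a six-membered non-aromatic ring. Nothing measured here accounts for the gain.

As far as these compounds go, whether it comes from the oxan-2-yl ring itself or from capping the oxygen at all stays open. A methyl ether or an amine at this place could answer that.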